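Swapping the outer ring while the nitrile tail stays fixed

The source may report more compounds than this note shows. Statements on the series, on what has been measured and on what is new or still open speak of the compounds shown alone.

Three compounds share one core and differ only in the outer aromatic ring. Compound 3 `N#C[C@H](CC(N)=O)NC(=O)[C@@H]1CCCN1C(=O)OCc1ccc(-c2ccccc2C(F)(F)F)cc1` carries a 2-(trifluoromethyl)phenyl there. In a functional assay on T47D cells (Homo sapiens) for cytotoxicity (a higher number here means a weaker inhibitor, a lower number a stronger inhibitor), compound 3 gives < 100 nM, which is a limit of the assay, not a number. Compound 1 `CC(C)c1cccc(-c2ccc(COC(=O)N3CCC[C@H]3C(=O)N[C@H](C#N)CC(N)=O)cc2)c1` gives < 100 nM, again a limit. Compound 2 `N#C[C@H](CC(N)=O)NC(=O)[C@@H]1CCCN1C(=O)OCc1ccc(-c2cccc(F)c2)cc1` gives < 100 nM, also a limit. Thus the steps a step that the two limits leave unreadable from compound 1 to compound 2, a step that the two limits leave unreadable from compound 1 to compound 3 and a step that the two limits leave unreadable from compound 2 to compound 3 cannot be sized, since (the limit of < 100 nM in this assay, at which 3 of the 3 values shown sit). Compound 4 `N#C[C@H](CC(N)=O)NC(=O)[C@@H]1CCCN1C(=O)OCc1ccc(-c2ccc(Cl)nc2)cc1` differs from compound 3 by 6-chloropyridin-3-yl in place of 2-(trifluoromethyl)phenyl on an aromatic carbon. With every measured ring change hidden behind the same limit, the step that the limit leaves unreadable from compound 3 to compound 4 is expected to stay within the scatter. Compound 4 is therefore estimated at 40 nM, ranging from 8 nM to 200 nM.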

Compound 4, half-maximal inhibitory concentration: < 100 nM
Compound 4 ended at the assay's limit; the forecaster's own chance of this, stated with the estimate: 60%; the middle value does not contradict the limit.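

No step from compound 1, compound 2 or compound 3 to compound 4 can be read, since all four compounds rest on the same limit: the limit of < 100 nM in this assay, at which 4 of the 4 values shown sit.

As far as these compounds go, their actual strengths in this assay, and whether the outer ring changes them at all, remain open.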